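Swapping the Phenyl on the Alkyne for a Cyclopropyl

This account rests on a few compounds, and the source may have more. Where it says the series, first, only, none or still open, it means among the compounds named here.

Compound 2 `O=c1[nH]c(=O)n([C@@H]2O[C@H](CO)[C@@H](O)[C@H]2O)cc1C#Cc1ccccc1` was tested in an ADME assay on A549 cells (Homo sapiens) for cytotoxicity, read by MTT assay (on this read-out lower numbers stand for higher toxicity in this test and higher numbers for lower toxicity in this test), where compound 2 gives 42500 nM. Its only measured companion, compound 1 `CCCCC#Cc1cn([C@@H]2O[C@H](CO)[C@@H](O)[C@H]2O)c(=O)[nH]c1=O`, gives 83200 nM in this assay. The step of a 2.0-fold lower number from compound 1 to compound 2 (0.29 log units; within the scatter) leaves these two numbers within the scatter of each other, so compound 2 stands side by side with compound 1 rather than apart from it, and both are only weakly toxic to these cells. Compound 3 `O=c1[nH]c(=O)n([C@@H]2O[C@H](CO)[C@@H](O)[C@H]2O)cc1C#CC1CC1` differs from compound 2 by cyclopropyl in place of phenyl on a triple-bonded carbon. Among the measured compounds shown here, the one measured step, butyl to phenyl on the same triple-bonded carbon, is the only guide, and it was small. Exchanging the phenyl for a cyclopropyl is therefore expected to give a 1.5-fold higher number from compound 2 to compound 3 (0.18 log units; within the scatter), a shift that stays inside the scatter. Compound 3 is accordingly estimated at 65000 nM, with a likely range from 25000 nM to 170000 nM.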

Compound 3, half-maximal cytotoxic concentration: 115000 nM
Estimate against measurement, compound 3: 1.8-fold (0.25 log units) below; the measured number falls inside the stated range.
By their numbers in this assay, from the lowest: compounds 2, 1 and 3 (each within the scatter of the next, the first and the last beyond it).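

Among the compounds shown here, at this triple-bonded carbon, the groups can be told apart in this assay, though only just: cyclopropyl in place of phenyl gives a 2.7-fold higher number from compound 2 to compound 3 (0.43 log units; beyond the scatter), the first step in this set to pass beyond the scatter, and a modest one. Cyclopropyl in place of butyl gives only a 1.4-fold higher number from compound 1 to compound 3 (0.14 log units; within the scatter), and compound 1 also lies within the scatter of compound 2, so only compound 2 and compound 3 can be separated, with compound 1 overlapping both. Nothing available here accounts for the difference between the phenyl and cyclopropyl compounds.

Open, on these data alone, is whether an amine, a carboxylic acid or a longer chain on this triple-bonded carbon would keep the number in the same range. Also open, as far as these compounds go, is whether the step from phenyl to cyclopropyl would hold on a different core.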